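The compounds below may be only part of what the source reports. "The series", "measured", "known", "first", "only" and "open" are said of these compounds alone.

Measured compounds:
compound 1, `Cc1nnc(CN2CCCC2)n1-c1ccc(Cl)cc1Cc1ccccc1`, 36 mg/kg
compound 2, `NCC(=O)Nc1ccc(Cl)cc1C(=O)c1ccccc1`, 0.25 mg/kg
compound 3, `Cc1nnc(CN)n1-c1ccc(Cl)cc1C(O)c1ccccc1`, 1.6 mg/kg

All three numbers come from a functional assay on the whole organism (strain CF-1) for inhibition, with Mus musculus as the target; on this read-out lower numbers stand for an effect already at smaller amounts and higher numbers for an effect only at larger amounts of compound. Within this set compound 1 gives the highest number; compound 3 stands nearest to it and compound 2 furthest, both gaps beyond the scatter. Compound 2 and compound 3 each hold an oxygen, as a carbonyl in compound 2 and as a hydroxyl in compound 3, that compound 1 lacks; compound 1 is the only one of the three with a plain benzyl on the shared core.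

Compound 4, `Cc1nnc(CN2CCCC2)n1-c1ccc(Cl)cc1C(=O)c1ccccc1`, is not yet measured in this assay. It differs from compound 1 in one place: benzoyl in place of benzyl on an aromatic carbon. Within the data shown here, no measured pair shows this exact step, so its size cannot be read from the series directly. Since compound 2 gives 0.25 mg/kg with a carbonyl on the same core, the step of a 7.2-fold lower number from compound 1 to compound 4 (0.86 log units; beyond the scatter) is expected to lower the number beyond the scatter, though compound 2 and compound 3 differ from compound 4 elsewhere as well, so the full gap need not carry over. The estimate for compound 4 in this assay is 5 mg/kg, with a range from 1.5 mg/kg to 15 mg/kg.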

Compound 4, dose for half-maximal effect: 0.4 mg/kg
Beside the measured number, compound 4's estimate is 13-fold (1.10 log units) above it; the measured number lies below the stated range.
By their numbers in this assay, from the lowest: compounds 2 and 4 (each within the scatter of the next); then compound 3; then compound 1.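

In this assay, among these compounds, benzoyl in place of benzyl on this aromatic carbon gives a 90-fold lower number from compound 1 to compound 4 (1.95 log units; beyond the scatter), the first step at this place that can be read with the rest of the molecule unchanged. The earlier compounds shown here carried their oxygen-bearing groups alongside other differences, whereas this pair ties the high number of compound 1 to the benzyl itself: the benzoyl adds an oxygen, a double bond outside aromatic rings and a hydrogen-bond acceptor, and nothing else in the structure changes. Nothing measured here says which of these features accounts for the step.

As far as these compounds go, with only benzyl and benzoyl compared on an otherwise identical structure, it remains open whether a sulfonyl or an ether oxygen on this aromatic carbon would give a number nearer to that of compound 1 or that of compound 4. Among the compounds shown here, also open is whether a fluoro group on the benzoyl ring, or a dimethylamine on the side chain in place of the one compound 4 carries, would keep the low number.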